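This account rests on a few compounds, and the source may have more. Where it says the series, first, only, none or still open, it means among the compounds named here.

Compound 1 `Cc1nnc(Sc2cc(NS(=O)(=O)c3ccc([N+](=O)[O-])cc3)ccc2O)s1` is one of three compounds that share a core carrying a hydroxy group, a sulfur-linked heteroaryl group and an amide or sulfonamide. In an assay on isolated protein for inhibition of RAC-alpha serine/threonine-protein kinase (Homo sapiens), read by fluorescence, with a stated time of 30 min, tested at 10 uM (a higher number here means more inhibition at the concentration tested (going by the name of the read-out), a lower number less inhibition), compound 1 gives 14.3%, the lower of the two numbers recorded: compound 3 `O=S(=O)(Nc1ccc(O)c(Sc2ncn[nH]2)c1)c1c(Cl)cccc1Cl` gives 48.4% in this assay, a gap beyond the usual scatter, while compound 2 `O=C(Nc1ccc(O)c(Sc2nncs2)c1)c1ccc([N+](=O)[O-])cc1` is reported in this assay as "not active" (no number reported), without a number. Compound 4 `O=[N+]([O-])c1ccc(S(=O)(=O)Nc2ccc(O)c(Sc3ncnc4nc[nH]c34)c2)cc1` is not yet measured in this assay; it differs from compound 1 in one place, (a group of 9 heavy atoms (5 carbon, 4 nitrogen; one five-membered aromatic ring with 2 hetero atoms, one six-membered aromatic ring with 2 hetero atoms) in place of a group of 6 heavy atoms (3 carbon, 2 nitrogen, 1 sulfur; one five-membered aromatic ring with 3 hetero atoms), on a sulfur). Within the data shown here, no measured pair isolates such a change, so the step is uncertain; a moderate rise from compound 1 is expected, a number 20.7 percentage points higher from compound 1 to compound 4 (beyond the scatter). Compound 4 is thus estimated to give 35% in this assay, within a range from 10% to 65%.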

Compound 4, a percentage reported as inhibition, at one concentration (the size of the read-out at that concentration, not a potency): 37.5%
Compound 4: the middle estimate sits 2.5 percentage points below what was measured, within the range that was stated.
By their numbers in this assay, from the lowest: compound 1; then compound 4; then compound 3.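

On the sulfur whose other neighbour is an aromatic carbon, the group can be changed with the rest of compound 1 held fixed, and in this assay putting the two-ring group in place of 5-methyl-1,3,4-thiadiazol-2-yl gives a number 23.2 percentage points higher from compound 1 to compound 4 (beyond the scatter). This single step shows that inhibition responds to this position and that the thiadiazole is not needed for it. Nothing measured here explains the rise. The compounds shown leave open whether the second ring or the hydrogen-bond donor accounts for the step. They also do not show how an amine or a carboxylic acid on a short chain would read on this sulfur.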